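This account rests on a few compounds, and the source may have more. Where it says the series, first, only, none or still open, it means among the compounds named here.

Working notes on the series. Three measured members share one core, each carrying a hydrazide linked to a sulfonyl group and a substituted benzene. In an ADME assay on microsomes from liver (Mus musculus) for metabolic stability, read by HPLC, using NADPH, with a stated time of 60 min, tested at 1 uM, in the presence of a further agent that is not named here (on this read-out lower numbers stand for a shorter-lived compound and higher numbers for a longer-lived compound), compound 1 `O=C(NNS(=O)(=O)c1ccccc1F)c1cc(F)cc(-n2cccn2)c1` gives 0.0833 h. Compound 2 `Cc1cc(-c2ncccn2)cc(C(=O)NNS(=O)(=O)c2ccccc2)c1F` gives 0.1 h in this assay, and compound 3 `Cc1cc(-c2ccccn2)cc(C(=O)NNS(=O)(=O)c2ccccc2)c1F` gives 0.0667 h. All three numbers sit within the usual scatter of one another; compound 1 has compound 2 as its nearest neighbour on this read-out and compound 3 as its furthest, and neither gap counts as a real difference. For the measured compounds named here, the single one-point step among them, a 1.5-fold lower number from compound 2 to compound 3 (0.18 log units; within the scatter), is itself within the scatter.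

The next member, compound 4 `C=CCOc1cc(F)cc(C(=O)NNS(=O)(=O)c2ccccc2F)c1`, differs from compound 1 in one place: allyloxy in place of 1H-pyrazol-1-yl on an aromatic carbon. Going by the values given here, no measured step touches this position or either of these groups; the only step in hand concerns the pyrimidin-2-yl and pyridin-2-yl groups and gave no change beyond the scatter. With nothing to point either way, the working expectation in this assay is a step of the size a 1.0-fold lower number from compound 1 to compound 4 (0.00 log units; within the scatter), that is, none beyond the scatter. Compound 4 is therefore expected to give about 0.083 h, within a range from 0.04 h to 0.17 h.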

Compound 4, half-life: 0.0333 h
Beside the measured number, compound 4's estimate is 2.5-fold (0.40 log units) above it; measured number outside the range, below it.
By their numbers in this assay, from the lowest: compounds 4, 3, 1 and 2 (each within the scatter of the next, the first and the last beyond it).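

In this assay, this position on an aromatic carbon, meta to a fluoro group and meta to a large group, responds to the change from 1H-pyrazol-1-yl to allyloxy, with a 2.5-fold lower number from compound 1 to compound 4 (0.40 log units; beyond the scatter). For the compounds shown here, this is the first one-point step to lie beyond the scatter, a modest one, whereas the only earlier step, a 1.5-fold lower number from compound 2 to compound 3 (0.18 log units; within the scatter), exchanged pyrimidin-2-yl for pyridin-2-yl and stayed within it. No measurement in hand gives a reason for the new step, so it stands as an observation on this one pair of compounds.

The change alters several things at once: a five-membered aromatic ring with 2 hetero atoms leaves, and an open group with an oxygen and a double bond outside aromatic rings enters, so the compounds shown cannot say which of these goes with the step. On these data alone, a propoxy chain, a methoxy group or an imidazole ring at this place would help separate them, and it remains open whether the same exchange gives a step of this size on the core of compound 2.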